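The compounds below may be only part of what the source reports. "The series", "measured", "known", "first", "only" and "open" are said of these compounds alone.

Working notes on the series. Going by the values given here, in an ADME assay on Vero cells (Chlorocebus sabaeus) for cytotoxicity, read by MTT assay, with a stated time of 48 h (on this read-out higher numbers stand for weaker inhibition and lower numbers for stronger inhibition), compound 2 `O=C(NC1CCC(CN2CCN(c3cc(=O)c4cc(C(F)(F)F)cc([N+](=O)[O-])c4s3)CC2)CC1)c1ccccc1` is the only member with a number; in this assay compound 2 gives 44.3 ug/mL. Compound 1 `CC(C)C(=O)OC1CCC(CN2CCN(c3cc(=O)c4cc(C(F)(F)F)cc([N+](=O)[O-])c4s3)CC2)CC1` is known in this assay only as a limit, > 64 ug/mL, which is a limit of the assay and not a number. Among the compounds with values here, the one measured step is an at least 1.4-fold lower number from compound 1 to compound 2 (0.15 log units; that floor lies within the scatter), and the step now followed, to compound 3 `CC(=O)OC1CCC(CN2CCN(c3cc(=O)c4cc(C(F)(F)F)cc([N+](=O)[O-])c4s3)CC2)CC1`, is acetoxy in place of benzamido on a saturated ring carbon. This change runs the other way from the measured one, an ester group again replacing the benzamido at the same saturated ring carbon, so a higher number is expected for compound 3, with the limit of > 64 ug/mL in this assay, at which 1 of the 2 values shown sits, marking where the ester-bearing compound 1 sits. The step is expected as a 1.3-fold higher number from compound 2 to compound 3 (0.12 log units; within the scatter). In this assay compound 3 is thus estimated at 58 ug/mL, between 35 ug/mL and 90 ug/mL.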

Compound 3, half-maximal inhibitory concentration: > 64 ug/mL
Compound 3: a limit, no number; the forecaster's own chance of this, stated with the estimate: 45%; middle value at least 1.1-fold (0.04 log units) from the limit.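

In this assay, acetoxy on this saturated ring carbon gives an at least 1.4-fold higher number from compound 2 to compound 3 (0.15 log units; that floor lies within the scatter). For compound 3, > 64 ug/mL is a limit of the assay and not a number. A second ester at this ring carbon therefore ends at the same limit as the first, while the step between the two esters, methyl in place of isopropyl on a carbonyl carbon, cannot be read, and the series' one number remains that of the benzamido compound: the limit of > 64 ug/mL in this assay, at which 2 of the 3 values shown sit.

Still open, as far as these compounds go, is whether the number for compound 2 goes with the amide link or with the phenyl ring, a question that acetamido or benzoyloxy on the same ring carbon would separate. Also open, from the compounds shown here alone, is how a free amine or a hydroxyl at this ring carbon would read in this assay.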